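Replacing 4-hydroxyphenyl with tert-butyl on the shared core

A few compounds are considered here, and "the series" means these few. Any claim that something is new, unique, unknown or untested is made for them only; others in the source may bear on it.

Compound 1 `CC/C=C\C[C@H]1C(=O)C=C[C@H]1CC(=O)Oc1ccc(O)cc1`: 49 uM
Compound 2 `CC/C=C\C[C@H]1C(=O)C=C[C@H]1CC(=O)OCCOCCOCCO`: 162 uM
Compound 3 `CC/C=C\C[C@H]1C(=O)C=C[C@H]1CC(=O)OCCOCCOCCOC`: 163 uM
Compound 4 `CC/C=C\C[C@H]1C(=O)C=C[C@H]1CC(=O)OC(C)(C)C`: not yet measured

In an ADME assay on RAW264.7 cells (Mus musculus) for cytotoxicity, read by MTT assay, with a stated time of 24 h (a lower number here means that less compound is tolerated, a higher number that more compound is tolerated), compound 1 gives 49 uM and stands lowest of the three, beyond the scatter from both others. Compound 4 differs from it by tert-butyl in place of 4-hydroxyphenyl on an oxygen next to a carbonyl group, with tert-butyl in place of 4-hydroxyphenyl on an oxygen next to a carbonyl group. For the measured compounds named here, no measured step covers this exchange. Going by the values given here, the one step available, a 1.0-fold higher number from compound 2 to compound 3 (0.00 log units; within the scatter), lies elsewhere and within the scatter. Among the compounds with values here, the only guide is that two compounds without 4-hydroxyphenyl, compound 2 at 162 uM and compound 3 at 163 uM, both lie higher, though they carry different groups. A modest rise is therefore expected, an estimated 2.2-fold higher number from compound 1 to compound 4 (0.35 log units; beyond the scatter) in this assay. For compound 4 the expected value is 110 uM, with an estimated range from 50 uM to 240 uM.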

Compound 4, half-maximal toxic concentration: 33 uM
For compound 4 the middle estimate is 3.3-fold (0.52 log units) above the measured one; measured number below the stated range.
By their numbers in this assay, from the lowest: compounds 4 and 1 (each within the scatter of the next); then compounds 2 and 3 (each within the scatter of the next).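

In this assay tert-butyl in place of 4-hydroxyphenyl on an oxygen next to a carbonyl group gives a 1.5-fold lower number from compound 1 to compound 4 (0.17 log units; within the scatter) and so leaves the number within the scatter. At this position, the six-membered aromatic ring and its hydrogen-bond donor can therefore be exchanged for a group with no ring and no donor without a change beyond the scatter. Nothing measured here accounts for this result. The compounds shown leave open where an amine or a carboxylic acid at this position would stand, and whether a longer chain would stay with compound 1 and compound 4 or reach the numbers of compound 2 and compound 3.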